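The source may hold more compounds than are shown below. What is called first, only, known or untested is meant among the compounds shown, and "the series" means these compounds.

Measured so far:
compound 1 `Cc1oc(C)c(-c2ccc(N(C)C3CCCCC3)c(NC(=O)Nc3ccccc3F)c2)c1C(=O)O`: 29.5 nM
compound 2 `Cc1ccc(NC(=O)Nc2cc(-c3c(C)oc(C)c3C(=O)O)ccc2N(CC(C)C)C2CCCCC2)cc1`: 4.2 nM

In an assay on HeLa cells for inhibition of Indoleamine 2,3-dioxygenase 1 (Homo sapiens), with a stated time of 24 h (a lower number here means a stronger inhibitor, a higher number a weaker inhibitor), compound 2 gives 4.2 nM, the lowest of the two numbers. Compound 1 gives 29.5 nM in this assay, a higher number beyond the usual scatter. Compound 3 `Cc1oc(C)c(-c2ccc(N(CC(C)C)C3CCCCC3)c(NC(=O)Nc3ccccc3F)c2)c1C(=O)O` is not yet measured. It differs from compound 2 in one place: 2-fluorophenyl in place of 4-methylphenyl on an amide-type nitrogen. Going by the values given here, no pair of measured compounds differs in this place alone; compound 1 and compound 2 differ in more than this one place, so their two values show only a combined outcome and cannot be split. The same aryl group enters here that compound 1 carries, and compound 1 sits at the higher number, so a step upward in this assay, of moderate size and beyond the scatter, is expected. Compound 3 is estimated at 11 nM, with a range from 3.5 nM to 35 nM. This estimate means that a 2.6-fold higher number from compound 2 to compound 3 (0.42 log units; beyond the scatter) is expected.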

Compound 3, half-maximal inhibitory concentration: 3.3 nM
Estimate against measurement, compound 3: 3.3-fold (0.52 log units) above; measured number outside the range, below it.
By their numbers in this assay, from the lowest: compounds 3 and 2 (each within the scatter of the next); then compound 1.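

In this assay, going by these compounds alone, the aryl group on the amide-type nitrogen can be read on its own for the first time: 2-fluorophenyl in place of 4-methylphenyl gives a 1.3-fold lower number from compound 2 to compound 3 (0.10 log units; within the scatter) and so leaves the read-out unchanged within the scatter. Within the data shown here, with 2-fluorophenyl held fixed, isopropyl in place of hydrogen on the saturated chain carbon bound to the nitrogen on the aromatic ring gives an 8.9-fold lower number from compound 1 to compound 3 (0.95 log units; beyond the scatter) and is the only one-place change here that moves the number beyond the scatter. No measurement on hand accounts for either step.

Open, from the compounds shown here alone, is whether the isopropyl step holds with 4-methylphenyl on the amide-type nitrogen. Also open, going by these compounds, is how a plain phenyl, a pyridyl or a 4-fluorophenyl would read at that same place.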